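Amide variation on the shared core: towards compound 4

The compounds below may be only part of what the source reports. "The series", "measured", "known", "first", "only" and "open" are said of these compounds alone.

Going by the values given here, compound 3 `CN1[C@@H]2c3[nH]c4ccccc4c3C[C@H]1[C@H](C#N)N1[C@@H](CNC(=O)c3cc4ccccc4s3)c3[nH]c4ccccc4c3C[C@@H]21` stands lowest of the three numbers so far. In a functional assay on HT-29 cells (Homo sapiens) for cytotoxicity, read by MTT assay, with a stated time of 72 h (on this read-out higher numbers stand for weaker inhibition and lower numbers for stronger inhibition), compound 3 gives 640 nM. Its nearest neighbour is compound 1 `COc1ccc(C(=O)NC[C@H]2c3[nH]c4ccccc4c3C[C@H]3[C@H]4c5[nH]c6ccccc6c5C[C@@H]([C@H](C#N)N23)N4C)cc1`, which gives 840 nM; the step of a 1.3-fold lower number from compound 1 to compound 3 (0.12 log units; within the scatter) separates them. Compound 2 `CN1[C@@H]2c3[nH]c4ccccc4c3C[C@H]1[C@H](C#N)N1[C@@H](CNC(=O)c3ccc(F)cc3)c3[nH]c4ccccc4c3C[C@@H]21` gives 1370 nM, and the step of a 2.1-fold lower number from compound 2 to compound 3 (0.33 log units; beyond the scatter) is the largest spread in the set. The remaining step, a 1.6-fold higher number from compound 1 to compound 2 (0.21 log units; within the scatter), shows how little the two aryl substituents move the number.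

Compound 4 `CN1[C@@H]2c3[nH]c4ccccc4c3C[C@H]1[C@H](C#N)N1[C@@H](CNC(=O)/C=C/c3cccc(C(F)(F)F)c3)c3[nH]c4ccccc4c3C[C@@H]21` continues the same exchange on the carbonyl carbon: 2-(3-(trifluoromethyl)phenyl)ethenyl in place of 1-benzothiophen-2-yl on a carbonyl carbon. Among the compounds with values here, the steps that bear on it are the two exchanges already made at this carbonyl, the one from compound 1 and the one from compound 2 to compound 3, both small and one of them within the scatter. Within the data shown here, the new group, however, carries an ethenyl spacer and no hydrogen-bond acceptor, a kind of change no measured pair covers, so the measured steps constrain only loosely.

The step of a 1.3-fold higher number from compound 3 to compound 4 (0.12 log units; within the scatter) is therefore expected to be small, towards a somewhat higher number. Compound 4 is expected to give about 850 nM, with a range from 350 nM to 2000 nM.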

Compound 4, half-maximal inhibitory concentration: 5060 nM
Beside the measured number, compound 4's estimate is 6.0-fold (0.77 log units) below it, outside the stated range (above it).
By their numbers in this assay, from the lowest: compounds 3, 1 and 2 (each within the scatter of the next, the first and the last beyond it); then compound 4.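

In this assay, going by these compounds alone, this exchange on the carbonyl carbon gives the clearest change so far: a 7.9-fold higher number from compound 3 to compound 4 (0.90 log units; beyond the scatter), a 6.0-fold higher number from compound 1 to compound 4 (0.78 log units; beyond the scatter) and a 3.7-fold higher number from compound 2 to compound 4 (0.57 log units; beyond the scatter), each beyond the scatter, while the widest step among the earlier groups is a 2.1-fold lower number from compound 2 to compound 3 (0.33 log units; beyond the scatter). The position therefore does not tolerate every acyl group equally: 2-(3-(trifluoromethyl)phenyl)ethenyl, with its double bond outside aromatic rings, gives a higher number than 4-methoxyphenyl, 4-fluorophenyl and 1-benzothiophen-2-yl, and weaker inhibition than all three. Nothing measured here accounts for this loss.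

The new group differs from the earlier ones in both its ethenyl unit and its trifluoromethyl group, so the compounds shown leave open which of the two goes with the higher number. On these data alone, a 3-(trifluoromethyl)phenyl group on the same carbonyl carbon, or an unsubstituted 2-phenylethenyl group, would separate the two, and the response of this position to an aryl group bearing an amine or a carboxylic acid also remains open.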